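A few compounds are considered here, and "the series" means these few. Any claim that something is new, unique, unknown or untested is made for them only; others in the source may bear on it.

Compound 1 `FC(F)(F)c1ccc(COc2ccccc2Nc2ncnc3cc4c(cc23)OCCOCCOCCO4)cc1` and compound 2 `FC(F)(F)c1ccc(COc2ccc(Nc3ncnc4cc5c(cc34)OCCOCCOCCOCCO5)cc2)cc1` are built on related cores; the difference between the two cores is not broken down here. In a functional assay on SH-SY5Y cells (Homo sapiens) for antiproliferative activity, read by MTT assay, with a stated time of 72 h (a higher number here means a weaker inhibitor, a lower number a stronger inhibitor), compound 2 gives 2140 nM. Compound 1, by contrast, reaches only a limit of this assay, giving > 100000 nM. Compound 3 `O=[N+]([O-])c1ccc(COc2ccc(Nc3ncnc4cc5c(cc34)OCCOCCOCCOCCO5)cc2)cc1` is compound 2 with nitro in place of trifluoromethyl on an aromatic carbon, and in this assay compound 3 likewise gives only a limit, > 100000 nM. That single change produces an at least 46-fold higher number from compound 2 to compound 3 (1.66 log units; beyond the scatter).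

Compound 4 `O=[N+]([O-])c1ccc(COc2ccccc2Nc2ncnc3cc4c(cc23)OCCOCCOCCO4)cc1`, not yet measured in this assay, carries the same change on the core of compound 1: nitro in place of trifluoromethyl on an aromatic carbon. Because compound 1 already sits at the limit of > 100000 nM in this assay, at which 2 of the 3 values shown sit, the change cannot be read as a step in the same way, and compound 4 is expected to sit at that limit as well, so the step that the limit leaves unreadable from compound 1 to compound 4 is an expectation, not a measured number. The estimate for compound 4 is 150000 nM, with the expected range running from 40000 nM to 600000 nM.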

Compound 4, half-maximal inhibitory concentration: 75500 nM
Beside the measured number, compound 4's estimate is 2.0-fold (0.30 log units) above it; the measured number falls inside the stated range.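

In this assay, nitro in place of trifluoromethyl gives an at least 1.3-fold lower number from compound 1 to compound 4 (0.12 log units; that floor lies within the scatter), a step that starts from a limit of the assay and so has only a floor. The change therefore does not carry over from one core to the other with the same outcome, since it is large and upward on the core of compound 2 but not on the core of compound 1: the same change on two cores in this assay, an at least 46-fold higher number (1.66 log units; beyond the scatter) from compound 2 to compound 3 and an at least 1.3-fold lower number (0.12 log units; that floor lies within the scatter) from compound 1 to compound 4, at least 61-fold (1.79 log units) apart, beyond the scatter of two such steps. What this does not show is the full size of either step or of the gap between them, since each step has a limit at one end: the limit of > 100000 nM in this assay, at which 2 of the 4 values shown sit.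

The two pairs do not settle which feature of the two cores goes with this gap, and two cores are too few to predict the change on a third. From the compounds shown here alone, it also remains open whether a nitrile or an amine in the same place would follow the pattern of compound 3 or of compound 4.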